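The compounds below may be only part of what the source reports. "The series", "measured", "known", "first", "only" and "open" are said of these compounds alone.

Measured compounds:
Compound 1 `CNc1nc(NCc2ccc(C(=O)Nc3ccc(F)cc3)cc2)c2ccccc2n1` — 2900 nM
Compound 2 `CCNc1nc(NCc2ccc(C(=O)Nc3ccc(F)cc3)cc2)c2ccccc2n1` — 1900 nM
Compound 3 `CCCCNc1nc(NCc2ccc(C(=O)Nc3ccc(F)cc3)cc2)c2ccccc2n1` — 1400 nM

These three share one core and differ only in the chain on the nitrogen of the shared core. In a functional assay on HCT-116 cells (Homo sapiens) for inhibition, read by luminescence and resazurin assay, with a stated time of 3 days (on this read-out lower numbers stand for stronger inhibition and higher numbers for weaker inhibition), compound 3 gives the lowest number of the three; the step of a 2.1-fold lower number from compound 1 to compound 3 (0.32 log units; beyond the scatter) is beyond the scatter, while the steps of a 1.5-fold lower number from compound 1 to compound 2 (0.18 log units; within the scatter) and a 1.4-fold lower number from compound 2 to compound 3 (0.13 log units; within the scatter) are not. Compound 4 `CC1CN(c2nc(NCc3ccc(C(=O)Nc4ccc(F)cc4)cc3)c3ccccc3n2)CCN1` carries a different change: 3-methylpiperazin-1-yl in place of butylamino on an aromatic carbon. The measured steps only lengthen a chain, so they bear weakly on a ring entering in its place; they show that growth at this spot lowered the number only modestly. For compound 4 a step of a 1.1-fold higher number from compound 3 to compound 4 (0.03 log units; within the scatter) is therefore expected, giving an estimated 1500 nM with a range from 500 nM to 5000 nM.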

Compound 4, half-maximal inhibitory concentration: 2800 nM
For compound 4 the middle estimate is 1.9-fold (0.27 log units) below the measured one; the measured number falls inside the stated range.
By their numbers in this assay, from the lowest: compounds 3, 2, 4 and 1 (each within the scatter of the next, the first and the last beyond it).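

In this assay a ring can stand on this aromatic carbon in place of a chain: a 2.0-fold higher number from compound 3 to compound 4 (0.30 log units; within the scatter) and a 1.5-fold higher number from compound 2 to compound 4 (0.17 log units; within the scatter) and a 1.0-fold lower number from compound 1 to compound 4 (0.02 log units; within the scatter) are the steps seen, so 3-methylpiperazin-1-yl cannot be told apart from any of the three chains. The earlier compounds shown here carried only open chains here, so they could not show this for a ring with a second nitrogen. Nothing measured here offers an explanation for this result.

From the compounds shown here alone, whether the methyl on the ring matters stays open. So does what piperazine without that methyl, morpholine or a longer chain would give at this position.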